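The source may hold more compounds than are shown below. What is called first, only, known or untested is meant among the compounds shown, and "the series" means these compounds.

Measured so far: compound 1 `COc1cc(/C=C2\CC/C(=C\c3ccc([N+](=O)[O-])cc3)C2=O)cc(OC)c1OC`, compound 2 `COc1cc(/C=C2\CCC/C(=C\c3ccc([N+](=O)[O-])cc3)C2=O)ccc1O`, compound 3 `COc1ccc(/C=C2\CCC/C(=C\c3ccc([N+](=O)[O-])cc3)C2=O)cc1OC`.

In a functional assay on HSG cells (Homo sapiens) for cytotoxicity (a higher number here means that more compound is tolerated, a lower number that less compound is tolerated), compound 1 gives only a limit, > 400000 nM. Compound 2 gives 11000 nM, the lowest of the two numbers shown. Compound 3 gives 13000 nM. Among the compounds with values here, the single one-point step on the phenol ring, a 1.2-fold higher number from compound 2 to compound 3 (0.07 log units; within the scatter), stays within the scatter.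

Compound 4 `O=C1/C(=C/c2ccc(O)cc2)CCC/C1=C\c1ccc([N+](=O)[O-])cc1` is still to be measured. Against compound 2 it carries hydrogen in place of methoxy on an aromatic carbon. Within the data shown here, no measured step removes a methoxy from this ring; the only nearby change, a 1.2-fold higher number from compound 2 to compound 3 (0.07 log units; within the scatter), altered the oxygen substituent without moving the number beyond the scatter. On that basis no step beyond the scatter is expected here either. Compound 4 is therefore estimated at 11000 nM (range 4000 nM to 30000 nM), the expected step being no change at the digits printed from compound 2 to compound 4 (within the scatter).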

Compound 4, half-maximal cytotoxic concentration: > 400000 nM
Compound 4: a limit, no number; the forecaster's own chance of this, stated with the estimate: 5%; middle value at least 36-fold (1.56 log units) away from the limit.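

On the 4-hydroxy-3-methoxyphenyl ring, the methoxy ortho to a hydroxy group proves to be a sensitive point in this assay: hydrogen in its place gives an at least 36-fold higher number from compound 2 to compound 4 (1.56 log units; beyond the scatter). The oxygen substituent change on the same ring, a 1.2-fold higher number from compound 2 to compound 3 (0.07 log units; within the scatter), gave no hint of this. Compound 4 gives only a limit, not a number: the limit of > 400000 nM in this assay, at which 2 of the 4 values shown sit.

Open, going by these compounds, is whether the methoxy itself is needed or any group on that carbon would serve; an ethoxy, a fluorine or an amine there would separate these. Within the data shown here, compound 1 differs from compound 2 in more than one place, so no step to it can be read.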